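The compounds below may be only part of what the source reports. "The series", "measured", "known", "first", "only" and "open" are said of these compounds alone.

Measured so far in a functional assay on the whole organism (artery, strain albino) with Rattus norvegicus as the target, with a stated time of 180 min, at a dose of 10 mg/kg by the oral route; on this read-out lower numbers stand for less inhibition and higher numbers for more inhibition at the one dose given (going by the name of the read-out):
compound 1, `COc1ccc(C2N=C(SCc3ccccc3Cl)NC(C)=C2C(=O)Nc2ccc(F)cc2)cc1OC`, gives 25.3%
compound 2, `CC1=C(C(=O)Nc2ccc(F)cc2)C(c2ccc([N+](=O)[O-])cc2)N=C(SCc2ccccc2)N1`, gives 23.7%

Compound 2 holds the lowest of the two numbers; its nearest neighbour is compound 1, and the gap between them lies within the scatter, so no order between the two can be read. Compound 3, `CC1=C(C(=O)Nc2ccc(F)cc2)C(c2ccc([N+](=O)[O-])cc2)N=C(SCc2ccccc2Cl)N1`, differs from compound 2 in one place: chloro in place of hydrogen on an aromatic carbon. Going by the values given here, no step between measured compounds separates this change on its own. The benzyl to 2-chlorobenzyl change is expected to give a step of a number 1.3 percentage points higher from compound 2 to compound 3 (within the scatter), not beyond the scatter in either direction. Compound 3 is therefore estimated at 25%, with a range from 12% to 40% in this assay.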

Compound 3, a percentage reported as inhibition, in the whole organism at one dose (the size of the read-out at that dose, not a potency): 12.4%
Compound 3: the middle estimate sits 12.6 percentage points above what was measured; the range from low to high includes it.
By their numbers in this assay, from the lowest: compound 3; then compounds 2 and 1 (each within the scatter of the next).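

Chloro in place of hydrogen, ortho to a large group, gives a number 11.3 percentage points lower from compound 2 to compound 3 (beyond the scatter) in this assay, so this position on the benzylsulfanyl group can shift the read-out. With 2-chlorobenzyl present in both compounds, 4-nitrophenyl in place of 3,4-dimethoxyphenyl on a saturated ring carbon gives a number 12.9 percentage points lower from compound 1 to compound 3 (beyond the scatter), so that site matters too. Nothing available explains either step.

From the compounds shown here alone, whether fluoro or an amine at the chloro position shifts the read-out the same way remains open. Going by these compounds, whether the chloro step holds with 3,4-dimethoxyphenyl in place of 4-nitrophenyl also remains open.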